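Swapping the aryl on the pyrazole nitrogen

This account rests on a few compounds, and the source may have more. Where it says the series, first, only, none or still open, it means among the compounds named here.

Measured compounds in an assay on CHO-K1 cells for antagonist activity at transient receptor potential cation channel subfamily V member 1 (Homo sapiens), read by FLIPR and calcium flux, with a stated time of 6 min; on this read-out lower numbers stand for stronger inhibition and higher numbers for weaker inhibition:
- compound 1 `O=C(NCc1cc(C(F)(F)F)nn1-c1cccc(C(F)(F)F)c1)Nc1cccc2[nH]ncc12`: 1.3 nM
- compound 2 `CC(C)(C)c1cc(CNC(=O)Nc2cccc3[nH]ncc23)n(-c2cccc(C(F)(F)F)c2)n1`: 0.3 nM

Compound 2 gives the lowest of the two numbers in this assay, and the step of a 4.3-fold lower number from compound 1 to compound 2 (0.64 log units; beyond the scatter) separates it from compound 1.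

Compound 3 `CC(C)(C)c1ccc(-n2nc(C(C)(C)C)cc2CNC(=O)Nc2cccc3[nH]ncc23)cc1` has not been measured in this assay. It differs from compound 2 by 4-(tert-butyl)phenyl in place of 3-(trifluoromethyl)phenyl on an aromatic nitrogen.

Going by the values given here, the one measured step exchanges tert-butyl for trifluoromethyl on an aromatic carbon of the five-membered ring, and that exchange was a 4.3-fold lower number from compound 1 to compound 2 (0.64 log units; beyond the scatter). Among the compounds with values here, the change to compound 3 also puts tert-butyl where trifluoromethyl stood, but on the ring carried by the aromatic nitrogen, and the group also moves to another position on that ring; no measured pair covers this. The precedent from compound 1 to compound 2 points in a favourable direction, yet the different ring weakens the analogy, and the number already sits very low.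

Compound 3 is therefore expected to stay close to compound 2, with a 2.0-fold higher number from compound 2 to compound 3 (0.30 log units; within the scatter) as the estimated step, and its estimated value is 0.6 nM with a range from 0.15 nM to 3 nM.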

Compound 3, inhibition constant: 40 nM
Beside the measured number, compound 3's estimate is 67-fold (1.82 log units) below it, outside the stated range (above it).
By their numbers in this assay, from the lowest: compound 2; then compound 1; then compound 3.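

In this assay, the aryl group on an aromatic nitrogen of the five-membered aromatic ring proves far more sensitive than the earlier exchange on the aromatic carbon showed: that exchange gave a 4.3-fold lower number from compound 1 to compound 2 (0.64 log units; beyond the scatter), whereas 4-(tert-butyl)phenyl in place of 3-(trifluoromethyl)phenyl gives a 130-fold higher number from compound 2 to compound 3 (2.12 log units; beyond the scatter), a large loss of inhibition. So a tert-butyl group that was tolerated on the carbon of the five-membered ring does not carry the same result over to the aryl ring on the nitrogen, even though the leaving and entering groups match in their count of 10 heavy atoms, in their single six-membered aromatic ring of carbon only, and in having no hydrogen-bond donors, acceptors or net charge. Nothing shown here gives a measured reason for this drop.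

The substituent and its place on the aryl ring change together in this one step, so the compounds shown cannot say which of the two accounts for the loss. On these data alone, how a plain phenyl, or a phenyl carrying a chlorine or a methoxy group, would behave on this nitrogen also stays open.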